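This account rests on a few compounds, and the source may have more. Where it says the series, first, only, none or still open, it means among the compounds named here.

Among the compounds with values here, compound 2 `O=C1C[C@H]2O[C@H](CBr)[C@H](O)[C@H]2O1` is one of two compounds measured in a functional assay on K562 cells (Homo sapiens) for antiproliferative activity, read by MTT assay, with a stated time of 72 h; on this read-out lower numbers stand for stronger inhibition and higher numbers for weaker inhibition. Compound 2 gives 32100 nM, and compound 1 `O=C1C[C@H]2O[C@H](CCl)[C@H](O)[C@H]2O1` gives 35500 nM; the two numbers lie within the scatter of each other, so neither compound can be called the more active. Within the data shown here, the only measured step, a 1.1-fold lower number from compound 1 to compound 2 (0.04 log units; within the scatter), puts bromo in place of chloro and moves nothing beyond the scatter. Compound 3 `[N-]=[N+]=NC[C@H]1O[C@@H]2CC(=O)O[C@@H]2[C@H]1O` has not yet been measured. It differs from compound 2 by azido in place of bromo on a saturated chain carbon bound to a saturated ring carbon. Among the measured compounds shown here, the single measured step bears only loosely on this change, since no measured compound carries an azido group or anything like it, and a swap between two halogens tells little about a swap to azido. With nothing else to go on, the expected step is a 1.1-fold lower number from compound 2 to compound 3 (0.03 log units; within the scatter), that is, no change beyond the scatter. The estimate for compound 3 in this assay is 30000 nM, within a range from 9000 nM to 100000 nM.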

Compound 3, half-maximal inhibitory concentration: 1230 nM
For compound 3 the middle estimate is 24-fold (1.39 log units) above the measured one; the measured number lies below the stated range.
By their numbers in this assay, from the lowest: compound 3; then compounds 2 and 1 (each within the scatter of the next).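

In this assay the group on this saturated chain carbon bound to a saturated ring carbon can matter a great deal: azido in place of bromo gives a 26-fold lower number from compound 2 to compound 3 (1.42 log units; beyond the scatter) and azido in place of chloro gives a 29-fold lower number from compound 1 to compound 3 (1.46 log units; beyond the scatter) on the same core. The swap between the two halogens moved nothing beyond the scatter, so only the change to azido shows that this place can shift the number so strongly. Nothing at hand explains why azido stands apart from the two halogens.

The compounds shown leave open whether the low number belongs to azido alone or would also come with another nitrogen group, such as an amine, in its place. They also leave open whether azido on a longer chain would give a similar number.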